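The source may hold more compounds than are shown below. What is called first, only, known or untested is meant among the compounds shown, and "the series" means these compounds.

In an ADME assay on L02 cells (Homo sapiens) for cytotoxicity, read by MTT assay, with a stated time of 24 h (a higher number here means a weaker inhibitor, a lower number a stronger inhibitor), compound 1 `O=C1/C(=C/c2cccnc2)CN(S(=O)(=O)c2ccccc2)C/C1=C\c1ccccc1C(F)(F)F` gives 12500 nM and compound 2 `O=C1/C(=C/c2cccnc2)CN(S(=O)(=O)c2ccc(Br)cc2)C/C1=C\c1ccccc1C(F)(F)F` gives 13300 nM. Among the measured compounds shown here, compound 2 therefore stands level with compound 1, its only measured neighbour, within the scatter. The next structure is compound 3 `N#Cc1ccc(S(=O)(=O)N2C/C(=C\c3cccnc3)C(=O)/C(=C/c3ccccc3C(F)(F)F)C2)cc1`, which differs from compound 2 by cyano in place of bromo on an aromatic carbon. This is cyano in place of bromo on an aromatic carbon, para to a large group. For the measured compounds named here, only one measured step bears on this change: a 1.1-fold higher number from compound 1 to compound 2 (0.03 log units; within the scatter), with bromo in place of hydrogen on an aromatic carbon. Going by the values given here, that step lies within the scatter, but it is a single step and no measured compound carries cyano, so the guidance is limited. No step beyond the scatter is expected in this assay, in either direction. The expected step is a 1.1-fold lower number from compound 2 to compound 3 (0.04 log units; within the scatter). For compound 3 the estimated value is 12000 nM, with an expected range of 5500 nM to 26000 nM.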

Compound 3, half-maximal inhibitory concentration: 13200 nM
The estimate for compound 3 lay 1.1-fold (0.04 log units) below the measured number; measured number inside the range.
By their numbers in this assay, from the lowest: compounds 1, 3 and 2 (each within the scatter of the next).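

In this assay the change from 4-bromophenyl to 4-cyanophenyl gives a 1.0-fold lower number from compound 2 to compound 3 (0.00 log units; within the scatter) and the addition of cyano to the unsubstituted ring gives a 1.1-fold higher number from compound 1 to compound 3 (0.02 log units; within the scatter). This place on the aromatic ring, para to a large group, has now carried hydrogen, bromo and cyano with no step beyond the scatter among the three compounds. Cyano also adds a triple bond and a hydrogen-bond acceptor that bromo lacks, and no evidence is available to explain why these differences leave the reading within the scatter.

Still open, on these data alone, is whether an amine, a carboxylic acid or a longer chain at this place would give a step beyond the scatter. The compounds shown also leave open whether changes elsewhere on the shared core, such as replacing the trifluoromethyl group, would move the number.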